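The source may hold more compounds than are shown below. What is called first, only, known or untested is meant among the compounds shown, and "the series" means these compounds.

Of the compounds shown here, three that share one core have been tested in an ADME assay for permeability, using PAMPA, with a stated time of 30 min, at pH 7.4; a lower number here means that the compound crosses the layer more slowly, a higher number that the compound crosses the layer faster. Compound 1 `COc1ccc(Oc2ccc3c(NCCCNCc4cc(F)ccc4OC)ccnc3c2)cc1` gives 317 10^-6 cm/s. Compound 2 `COc1ccc(F)cc1CNCCCNc1ccnc2cc(CCC(C)C)ccc12` gives 23 10^-6 cm/s, and compound 3 `COc1ccc(F)cc1CNCCCNc1ccnc2cc(CC(C)C)ccc12` gives 23 10^-6 cm/s. Among these numbers compound 3 stands level with compound 2, and together they are the lowest of the three; compound 1 is the furthest away. The steps from compound 1 are large: a 14-fold lower number from compound 1 to compound 2 (1.14 log units; beyond the scatter) and a 14-fold lower number from compound 1 to compound 3 (1.14 log units; beyond the scatter). Between the two alkyl compounds there is no change at the digits printed from compound 2 to compound 3 (within the scatter).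

Compound 4 `COc1ccc(F)cc1CNCCCNc1ccnc2cc(Oc3ccc(C(C)(C)C)cc3)ccc12` has not yet been measured. It differs from compound 3 in one place: 4-(tert-butyl)phenoxy in place of isobutyl on an aromatic carbon. The step that bears most on this change is a 14-fold lower number from compound 1 to compound 3 (1.14 log units; beyond the scatter), in which an isobutyl group took the place of a 4-methoxyphenoxy group on the same aromatic carbon. Compound 4 runs that exchange in the opposite direction, putting a phenoxy group back onto that carbon, so a large rise is expected, roughly back toward the number of compound 1. On that basis compound 4 is expected to give about 250 10^-6 cm/s, within a range from 100 10^-6 cm/s to 550 10^-6 cm/s. This estimate corresponds to an expected step of an 11-fold higher number from compound 3 to compound 4 (1.04 log units; beyond the scatter).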

Compound 4, apparent permeability: 317 10^-6 cm/s
Estimate against measurement, compound 4: 1.3-fold (0.10 log units) below, and the stated range covers the measured number.
By their numbers in this assay, from the lowest: compounds 2 and 3 (each within the scatter of the next); then compounds 1 and 4 (each within the scatter of the next).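

In this assay the return of a phenoxy group to this aromatic carbon gives a 14-fold higher number from compound 3 to compound 4 (1.14 log units; beyond the scatter), and the step from the longer alkyl group is the same size, a 14-fold higher number from compound 2 to compound 4 (1.14 log units; beyond the scatter), so the earlier fall can be reversed starting from either isobutyl or isopentyl. The substituent carried on the phenoxy ring, by contrast, makes no visible difference here: tert-butyl in place of methoxy gives no change at the digits printed from compound 1 to compound 4 (within the scatter), which shows that the high number does not depend on the methoxy group and survives this exchange. Across these four compounds, the two with a phenoxy group at this position sit together high and the two with an alkyl group sit together low, and none of the four goes against that split. No measurement is available here to explain why the numbers divide this way.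

The entering group brings an oxygen and a six-membered aromatic ring together, so the compounds shown cannot tell which of the two goes with the high number. A phenyl ring joined directly to the aromatic carbon, or a phenoxy ring carrying a carboxylic acid or an amine, would test how far the split holds.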